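The source may hold more compounds than are shown below. What is called first, only, known or untested is meant among the compounds shown, and "the series" means these compounds.

Measured so far:
compound 1 `Cc1nc(Nc2c(Cl)cc(C(F)(F)F)cc2Cl)c(=O)n(C(C)C2CC2)n1`: 14 nM
compound 2 `CCC(C1CC1)n1nc(C)nc(Nc2c(Cl)cc(C(F)(F)F)cc2Cl)c1=O`: 6.3 nM

In an assay on isolated protein for displacement of a labelled ligand from corticotropin-releasing factor receptor 1 (Rattus norvegicus) (a lower number here means a stronger inhibitor, a higher number a weaker inhibitor), compound 1 gives 14 nM, the higher of the two numbers recorded; compound 2 gives 6.3 nM. Within the data shown here, the one measured step, a 2.2-fold lower number from compound 1 to compound 2 (0.35 log units; beyond the scatter), is a methyl in place of hydrogen on a saturated chain carbon, two bonds along the chain from an aromatic nitrogen and a saturated ring carbon.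

Compound 3 `Cc1nc(Nc2c(Cl)cc(OC(F)(F)F)cc2Cl)c(=O)n(C(C)C2CC2)n1` keeps the chain of compound 1 and differs from it only on the aryl ring: trifluoromethoxy in place of trifluoromethyl on an aromatic carbon. Among the measured compounds shown here, the measured step concerns the chain, not the aromatic carbon that changes here, so it gives no guide to this change; the numbers so far hold no comparison of trifluoromethyl with trifluoromethoxy. With nothing to argue either way, the expectation is a step no larger than the scatter, no change at the digits printed from compound 1 to compound 3 (within the scatter). Compound 3 is therefore estimated at 14 nM, in a range from 5 nM to 40 nM.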

Compound 3, half-maximal inhibitory concentration: 39 nM
For compound 3 the middle estimate is 2.8-fold (0.44 log units) below the measured one, and the stated range covers the measured number.
By their numbers in this assay, from the lowest: compound 2; then compound 1; then compound 3.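

In this assay the aromatic carbon para to a large group proves sensitive to a small change: trifluoromethoxy in place of trifluoromethyl gives a 2.8-fold higher number from compound 1 to compound 3 (0.44 log units; beyond the scatter) and so moves the number in the weaker direction. Substitution on the aryl ring therefore matters as well as the chain, where the one earlier step, a 2.2-fold lower number from compound 1 to compound 2 (0.35 log units; beyond the scatter), ran towards a stronger inhibitor. Nothing on hand accounts for the loss seen with trifluoromethoxy.

Whether the trifluoromethoxy step holds on the chain of compound 2 remains open, as the pair that would test it is absent from the compounds shown. Also open, going by these compounds, is how other groups at this aromatic carbon, such as a methoxy, a nitrile or a plain chloro, would compare with trifluoromethyl.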